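Moving the Chlorine Around the Sulfonyl Ring

A few compounds are considered here, and "the series" means these few. Any claim that something is new, unique, unknown or untested is made for them only; others in the source may bear on it.

In a functional assay on MCF7 cells (Homo sapiens) for antiproliferative activity, read by MTT assay, with a stated time of 48 h (a lower number here means a stronger inhibitor, a higher number a weaker inhibitor), compound 2 `O=C(/C=C/c1cccc(NS(=O)(=O)c2cccc(Cl)c2)c1)c1nc2ccccc2[nH]1` gives 4160 nM. Among the measured compounds shown here, the only other measured compound, compound 1 `Cc1cccc(C(=O)Nc2cccc(/C=C/C(=O)c3nc4ccccc4[nH]3)c2)c1`, gives 5590 nM, and the two numbers sit within the scatter of each other, as a 1.3-fold lower number from compound 1 to compound 2 (0.13 log units; within the scatter) shows. Compound 3 `O=C(/C=C/c1cccc(NS(=O)(=O)c2ccc(Cl)cc2)c1)c1nc2ccccc2[nH]1` differs from compound 2 by 4-chlorophenyl in place of 3-chlorophenyl on a sulfonyl sulfur. For the measured compounds named here, no measured step moves a substituent around that ring; the single measured step exchanges a whole group on the nitrogen. With nothing bearing directly on this change, the expected step is none beyond the scatter, a 1.0-fold higher number from compound 2 to compound 3 (0.00 log units; within the scatter). Compound 3 is therefore estimated at 4200 nM, in the range 1500 nM to 12000 nM.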

Compound 3, half-maximal inhibitory concentration: 3820 nM
For compound 3 the middle estimate is 1.1-fold (0.04 log units) above the measured one; the measured number falls inside the stated range.
By their numbers in this assay, from the lowest: compounds 3, 2 and 1 (each within the scatter of the next).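

Moving the chlorine, with 4-chlorophenyl in place of 3-chlorophenyl on a sulfonyl sulfur, gives a 1.1-fold lower number from compound 2 to compound 3 (0.04 log units; within the scatter) and so no change beyond the scatter at this position. Setting (4-chlorophenyl)sulfonyl in place of (3-methylphenyl)carbonyl on the nitrogen gives a 1.5-fold lower number from compound 1 to compound 3 (0.17 log units; within the scatter) and likewise stays within the scatter. No evidence is available that would explain either step.

As far as these compounds go, whether an amine, a carboxylic acid or a methoxy group in place of the chlorine on this ring would move the number beyond the scatter remains open.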